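This account rests on a few compounds, and the source may have more. Where it says the series, first, only, none or still open, it means among the compounds named here.

Measured compounds:
compound 1 `Fc1ccc(Nc2cc(Nc3ccc(Oc4ccncc4-c4cccnc4)c(F)c3)ncn2)cc1F` with 6770 nM in a functional assay on MDA-MB-231 cells (Homo sapiens) for cytotoxicity, read by MTT assay, with a stated time of 72 h; on this read-out lower numbers stand for stronger inhibition and higher numbers for weaker inhibition
compound 2 `Fc1cc(Nc2cc(Nc3ccc(Cl)cc3)ncn2)ccc1Oc1ccncc1-c1cccnc1` with "not determined" (no result reported)
compound 3 `Fc1cc(Nc2cc(Nc3cccc(Cl)c3)ncn2)ccc1Oc1ccncc1-c1cccnc1` with 90 nM

Compound 3 stands at the lowest number of the two that were measured, and its nearest neighbour is compound 1, which lies far above it; the step of a 75-fold lower number from compound 1 to compound 3 (1.88 log units; beyond the scatter) shows how much the exchange of one group on the nitrogen of the shared core can move the read-out. Compound 2 carries a related but differently placed group on that nitrogen and gives no number, so it adds nothing to the comparison.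

Compound 4 `COc1cc(Nc2cc(Nc3ccc(Oc4ccncc4-c4cccnc4)c(F)c3)ncn2)cc(OC)c1` differs from compound 3 in one place: 3,5-dimethoxyphenyl in place of 3-chlorophenyl on a nitrogen on an aromatic ring. Within the data shown here, the only measured step at this position, a 75-fold lower number from compound 1 to compound 3 (1.88 log units; beyond the scatter), was large, which shows that the identity of the group on this nitrogen matters strongly, but it does not say in which direction an exchange of a 3-chlorophenyl for a 3,5-dimethoxyphenyl should go. Among the measured compounds shown here, with only that one step as a guide, compound 4 is expected to sit somewhat above compound 3, with the step of a 6.7-fold higher number from compound 3 to compound 4 (0.82 log units; beyond the scatter) estimated to go towards weaker inhibition. The estimate for compound 4 is 600 nM, expected to lie between 120 nM and 4000 nM.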

Compound 4, half-maximal inhibitory concentration: 4240 nM
Compound 4: middle estimate off by 7.1-fold (0.85 log units), on the low side, and the stated range ends below it.
By their numbers in this assay, from the lowest: compound 3; then compounds 4 and 1 (each within the scatter of the next).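

In this assay, a second exchange at this nitrogen also produces a large change (a 47-fold higher number from compound 3 to compound 4 (1.67 log units; beyond the scatter)). The low number of compound 3 is therefore no longer set against a single group: 3-chlorophenyl now stands apart from both 3,4-difluorophenyl and 3,5-dimethoxyphenyl. The remaining comparison (a 1.6-fold lower number from compound 1 to compound 4 (0.20 log units; within the scatter)) shows that these last two groups cannot be told apart in this assay, even though one carries fluorine atoms and the other methoxy groups, so a marked change in the substituents on this ring does not always move the number. Nothing in the data shown explains why 3-chlorophenyl stands apart.

On these data alone, compound 2 has no number, so steps involving it cannot be read, and whether the low number depends on where the chlorine sits on the ring remains open. It is also unknown whether the low number depends on chlorine itself, which a 3-bromophenyl or 3-methylphenyl group on this nitrogen could help to show.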